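Swapping the N-aryl ring of a pyrazolinone ACAT inhibitor

A few compounds are considered here, and "the series" means these few. Any claim that something is new, unique, unknown or untested is made for them only; others in the source may bear on it.

Measured compounds in an assay on microsomes from intestine for inhibition of acyl-CoA:cholesterol acyltransferase (Oryctolagus cuniculus); on this read-out lower numbers stand for stronger inhibition and higher numbers for weaker inhibition:
- compound 1 `Cc1cccc(C)c1N1N=C(CC(c2ccccc2)c2ccccc2)CC1=O`: 50800 nM
- compound 2 `CC(C)c1cccc(C(C)C)c1N1CNC(C(c2ccccc2)c2ccccc2)C1=O`: 3900 nM
- compound 3 `CCCCCCCC/C=C\CCCCCCCC1=NN(c2c(Cl)cccc2Cl)C(=O)C1`: 22900 nM

Of the three numbers, compound 3 stands second highest. Its nearest neighbour is compound 1, whose number is higher by a gap beyond the usual scatter; compound 2 lies furthest away, with a lower number, again beyond the scatter. Compound 3 thus sits between the two other measured compounds, closer to the weaker end.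

Compound 4 `CCCCCCCC/C=C\CCCCCCCC1=NN(c2ccc(F)cc2F)C(=O)C1` is the next compound in this series. The change from compound 3 is 2,4-difluorophenyl in place of 2,6-dichlorophenyl on an amide-type nitrogen in a ring. For the measured compounds named here, no measured pair in the set shows this kind of exchange, so there is nothing in the numbers that directly foretells its effect. The ring on the amide-type nitrogen is kept, and only the two halogens and their positions change.

Without a measured precedent, the expected step is a modest one, with the number somewhat higher rather than lower, roughly at the edge of the scatter: the estimated step of a 1.7-fold higher number from compound 3 to compound 4 (0.24 log units; within the scatter) reflects that. Compound 4 is therefore estimated at 40000 nM, with a range from 12000 nM to 130000 nM.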

Compound 4, half-maximal inhibitory concentration: 5000 nM
Estimate against measurement, compound 4: 8.0-fold (0.90 log units) above; the measured number lies below the stated range.
By their numbers in this assay, from the lowest: compounds 2 and 4 (each within the scatter of the next); then compound 3; then compound 1.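

In this assay the group on the amide-type nitrogen proves to matter: a 4.6-fold lower number from compound 3 to compound 4 (0.66 log units; beyond the scatter) comes with 2,4-difluorophenyl in place of 2,6-dichlorophenyl, while the long chain and the shared core stay the same. For the compounds shown here, this is the first pair in the set that differs in one place, and it shows that changing only the halogens and their positions on this ring moves the number beyond the scatter. Nothing measured here gives a reason for this step.

The halogen and its positions change together, so the step cannot show whether fluorine or the new placement carries the effect. Also open, from the compounds shown here alone, is how a plain phenyl, a 2,4-dichlorophenyl or a pyridine ring would fare on this nitrogen, and whether the stronger inhibition would persist with a shorter chain.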